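Fluoro in place of nitro on a weak compound

The compounds below may be only part of what the source reports. "The series", "measured", "known", "first", "only" and "open" are said of these compounds alone.

In a functional assay on CCRF-CEM cells (Homo sapiens) for inhibition, read by MTT assay, with a stated time of 72 h (a lower number here means a stronger inhibitor, a higher number a weaker inhibitor), compound 1 (`COc1cc(-c2c(-c3ccc4[nH]ccc4c3)c(=O)c2=O)cc(OC)c1OC`) gives 15.4 nM as its value, while compound 2 (`COc1ccc(-c2c(-c3cc(OC)c(OC)c(OC)c3)c(=O)c2=O)cc1[N+](=O)[O-]`) gives 12200 nM as its value. Compound 2 therefore holds the higher of the two numbers, and its gap to compound 1 lies well beyond the scatter.

The next entry is compound 3 (`COc1ccc(-c2c(-c3cc(OC)c(OC)c(OC)c3)c(=O)c2=O)cc1F`), which keeps the core of compound 2 and carries fluoro in place of nitro on an aromatic carbon. The site is ortho to a methoxy group and meta to a large group. Within the data shown here, no measured pair shows this change, so the expectation is loose. Compound 1 at 15.4 nM shows how low a number the series can reach, and compound 2 at 12200 nM sits far from it. Expected in this assay is a sizeable move toward lower numbers, beyond the scatter (a 14-fold lower number from compound 2 to compound 3 (1.13 log units; beyond the scatter)). Compound 3 is estimated at 900 nM as a middle value, with an expected range from 120 nM to 6000 nM for the coming measurement.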

Compound 3, half-maximal inhibitory concentration: 11.5 nM
The estimate for compound 3 lay 78-fold (1.89 log units) above the measured number; the whole stated range lies above it.
By their numbers in this assay, from the lowest: compounds 3 and 1 (each within the scatter of the next); then compound 2.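

In this assay, among these compounds, the aromatic carbon ortho to a methoxy group and meta to a large group turns out to be highly sensitive to what it carries: fluoro in place of nitro gives the first reading of any change at this site (a 1100-fold lower number from compound 2 to compound 3 (3.03 log units; beyond the scatter)), so the weak number of compound 2 does not extend to compound 3, which keeps the rest of the structure unchanged. With 3-fluoro-4-methoxyphenyl in place of 1H-indol-5-yl (a 1.3-fold lower number from compound 1 to compound 3 (0.13 log units; within the scatter)), the two groups cannot be told apart in these numbers, and the low end of the series is reached with more than one group. No measurement at hand bears on why nitro and fluoro part so widely here, and the step stands as an observation only.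

Open is how this site responds to chloro, an amine, a carboxylic acid or plain hydrogen, since the compounds shown carry only nitro and fluoro there. Also open, from the compounds shown here alone, is whether the match between compound 1 and compound 3 survives a change elsewhere on the shared core.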